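The source may hold more compounds than are shown below. What is called first, only, known or untested is meant among the compounds shown, and "the series" means these compounds.

Measured so far in a functional assay on A549 cells (Homo sapiens) for cytotoxicity, read by MTT assay, with a stated time of 72 h; on this read-out lower numbers stand for stronger inhibition and higher numbers for weaker inhibition:
- compound 1 `Cc1ccccc1NC(=O)CN1CCN(c2nnc(Cc3ccccc3)c3ccccc23)CC1` gives "not active" (no number reported)
- compound 2 `O=C(CN1CCN(c2nnc(Cc3ccncc3)c3ccccc23)CC1)Nc1ccc(F)c(Cl)c1` gives 12300 nM
- compound 3 `Cc1ccccc1NC(=O)CN1CCN(c2nnc(Cc3ccncc3)c3ccccc23)CC1` gives 43100 nM

Compound 1 has no number to serve as a starting point: in this assay compound 1 is recorded only as "not active" (no number reported), so any step away from it cannot be sized exactly.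

Compound 4 `O=C(CN1CCN(c2nnc(Cc3ccccc3)c3ccccc23)CC1)Nc1cccc(Br)c1` keeps the core of compound 1 and changes one group: 3-bromophenyl in place of 2-methylphenyl on an amide-type nitrogen. In words, 3-bromophenyl stands in place of 2-methylphenyl on an amide-type nitrogen. Within the data shown here, the only measured step that bears on this is a 3.5-fold higher number from compound 2 to compound 3 (0.54 log units; beyond the scatter), a modest change beyond the scatter, with 2-methylphenyl in place of 3-chloro-4-fluorophenyl on the same kind of nitrogen. That step comes from compounds with a different group elsewhere, so it is only a loose guide. Read in reverse, it points to a modest step towards a lower number when a halogen-bearing phenyl replaces 2-methylphenyl, so compound 4 is expected to give a measurable but weak value.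

For compound 4 the estimated value is 22000 nM, with an expected range from 7000 nM to 70000 nM in this measurement.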

Compound 4, half-maximal inhibitory concentration: "not active" (no number reported)
No number was reported for compound 4; no gap can be computed for the estimate.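

Among these compounds, compound 1 and compound 4 both stand without a number in this assay and so no step between them can be read. No measurement shown offers an explanation for this result. The compounds shown leave open whether any group on the amide-type nitrogen gives a measurable value on the core of compound 1.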